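A few compounds are considered here, and "the series" means these few. Any claim that something is new, unique, unknown or untested is made for them only; others in the source may bear on it.

Compound 1 `CN1CCN(CCCN(C[C@H]2Cc3ccccc3CN2)[C@H]2CCCc3cccnc32)CC1` gives 125 nM; compound 2 `c1ccc2c(c1)CN[C@@H](CN(CC[C@H]1CCCNC1)[C@H]1CCCc3cccnc31)C2` gives 16 nM; compound 3 `c1cnc(CN(CCCN2CCNCC2)[C@H]2CCCc3cccnc32)nc1` gives 4320 nM, all in a functional assay on CCRF-CEM cells for antagonist activity at C-X-C chemokine receptor type 4 (Homo sapiens), read by calcium flux, with stated times of 25 min and 90 s; a lower number here means a stronger inhibitor, a higher number a weaker inhibitor.

Compound 3 stands highest of the three, far from compound 1 and still further from compound 2, so it is the weakest inhibitor here. Compound 4 `c1ccc2c(c1)CN[C@H](CN(CCCN1CCNCC1)[C@H]1CCCc3cccnc31)C2` carries 1,2,3,4-tetrahydroisoquinolin-3-yl in place of pyrimidin-2-yl on a saturated chain carbon bound to an amine nitrogen. Among the measured compounds shown here, no measured step matches this change directly. For the measured compounds named here, the only measured step, a 7.8-fold lower number from compound 1 to compound 2 (0.89 log units; beyond the scatter), touches a different part of the molecule. What the numbers do show is that both compounds bearing the tetrahydroisoquinolinyl group, compound 1 and compound 2, sit far lower than compound 3. Compound 4 is therefore expected to fall well below compound 3, near compound 1, an estimated 43-fold lower number from compound 3 to compound 4 (1.64 log units; beyond the scatter). Compound 4 is estimated at 100 nM, within 25 nM to 400 nM.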

Compound 4, half-maximal inhibitory concentration: 1150 nM
The estimate for compound 4 lay 12-fold (1.06 log units) below the measured number; measured number outside the range, above it.
By their numbers in this assay, from the lowest: compound 2; then compound 1; then compound 4; then compound 3.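

Among the compounds shown here, putting 1,2,3,4-tetrahydroisoquinolin-3-yl in place of pyrimidin-2-yl on a saturated chain carbon bound to an amine nitrogen gives a 3.8-fold lower number from compound 3 to compound 4 (0.57 log units; beyond the scatter), the first direct reading of this change. This position therefore responds to the swap, but the step is only modest and rests on a single pair. Nothing available explains its size.

On these data alone, it remains open whether a phenyl group on the same carbon would behave more like pyrimidin-2-yl or more like 1,2,3,4-tetrahydroisoquinolin-3-yl. As far as these compounds go, the same step on a different chain also remains untested by these compounds.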